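Cutting the sulfonamide arm down to a hydroxyl

The compounds below may be only part of what the source reports. "The series", "measured", "known", "first", "only" and "open" are said of these compounds alone.

Compound 1 `Cc1ccc(S(=O)(=O)NCc2cn(C[C@H](O)[C@H]3OC(=O)C(OCc4ccccc4)=C3OCc3ccccc3)nn2)cc1`: 13100 nM
Compound 2 `O=C1O[C@H]([C@@H](O)Cn2cc(-c3cc(F)cc(F)c3)nn2)C(OCc2ccccc2)=C1OCc1ccccc1`: 48200 nM
Compound 3 `Cc1ccc(-c2cn(C/C=C3\OC(=O)C(OCc4ccccc4)=C3OCc3ccccc3)nn2)cc1`: > 100000 nM

Of the compounds shown here, three share a core and have been tested in a functional assay on HCT-116 cells (Homo sapiens) for antiproliferative activity, read by MTT assay, with a stated time of 72 h; a higher number here means a weaker inhibitor, a lower number a stronger inhibitor. Compound 1 gives 13100 nM, the lower of the two numbers recorded. Compound 2 gives 48200 nM. The value recorded for compound 3 is a limit of the assay, > 100000 nM, and not a number. One measured step connects the numbers: a 3.7-fold higher number from compound 1 to compound 2 (0.57 log units; beyond the scatter), where compound 2 carries a 3,5-difluorophenyl in place of the (((4-methylphenyl)sulfonyl)amino)methyl of compound 1.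

Compound 4 `O=C1O[C@H]([C@@H](O)Cn2cc(CCO)nn2)C(OCc2ccccc2)=C1OCc1ccccc1` has not been measured in this assay. It differs from compound 1 in one place: hydroxymethyl in place of ((4-methylphenyl)sulfonyl)amino on a saturated chain carbon bound to an aromatic carbon. Among the compounds with values here, the only measured step bears on it indirectly, since it replaces the same arm of compound 1 with an aromatic group rather than a small hydroxyl, and that change gave a modest weakening. For compound 4 the arm is removed almost entirely, and a loss of the same order or somewhat larger is therefore expected, the step being estimated as a 2.7-fold higher number from compound 1 to compound 4 (0.43 log units; beyond the scatter). Compound 4 is thus expected to give about 35000 nM, within a range of 10000 nM to 100000 nM.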

Compound 4, half-maximal inhibitory concentration: 72700 nM
Compound 4: middle estimate off by 2.1-fold (0.32 log units), on the low side, and the stated range covers the measured number.
By their numbers in this assay, from the lowest: compound 1; then compounds 2 and 4 (each within the scatter of the next). At a limit, above all of these: compound 3.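

In this assay, setting hydroxymethyl in place of ((4-methylphenyl)sulfonyl)amino gives a 5.5-fold higher number from compound 1 to compound 4 (0.74 log units; beyond the scatter), so the loss seen at this arm now appears with a small group without a ring as well as with the 3,5-difluorophenyl of compound 2. The two replacements themselves cannot be told apart in this assay, with a 1.5-fold higher number from compound 2 to compound 4 (0.18 log units; within the scatter), and 2-hydroxyethyl and 3,5-difluorophenyl on the aromatic carbon therefore cannot be ranked against each other. Among the three compounds with numbers, the lowest number stays with the sulfonyl-bearing arm of compound 1, and nothing measured here gives a reason for these steps.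

On these data alone, it remains open which part of the ((4-methylphenyl)sulfonyl)amino group matters, the 4-methylphenyl ring or the sulfonyl link, and how an amine, a carboxylic acid or a longer chain ending in a phenyl ring would read at the same saturated chain carbon. Compound 3 gives a limit of the assay and not a number, and it differs from compound 1 in more than one place, so it settles nothing about this arm: the limit of > 100000 nM in this assay, at which 1 of the 4 values shown sits.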